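One Methyl Less: What Compound 4 Should Show

The source may report more compounds than this note shows. Statements on the series, on what has been measured and on what is new or still open speak of the compounds shown alone.

Measured compounds:
- compound 1, `COc1cc(OC)c(OC)cc1/C=C/C(=O)c1ccc(C)cc1`: 2.18 ug/mL
- compound 2, `COc1cc(OC)c(OC)cc1/C=C/C(=O)c1cc(OC(C)=O)ccc1OC(C)=O`: 2.37 ug/mL
- compound 3, `COc1cc(OC)c(OC)cc1/C=C/C(=O)c1cc(Cc2ccccc2)cc(Cc2ccccc2)c1`: 2.09 ug/mL

All three were tested in a functional assay, read by Griess assay, with a stated time of 2.5 h; a higher number here means a weaker inhibitor, a lower number a stronger inhibitor. Compound 1 stands second highest of the three numbers, but the spread is tiny: its nearest neighbour is compound 3, whose value lies within the scatter, and its furthest is compound 2, whose value also lies within the scatter. The three compounds share the same core and differ only in the groups carried on one of the two rings, yet the groups there range from a single methyl to two acetate groups to two benzyl groups without any of them moving the number beyond what repeated measurements of one compound would give.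

Compound 4, `COc1cc(OC)c(OC)cc1/C=C/C(=O)c1ccccc1`, has not yet been measured in this assay. It differs from compound 1 by hydrogen in place of methyl on an aromatic carbon, that is, a 4-methylphenyl becomes a plain phenyl. Given that much larger changes on the same ring left compound 2 and compound 3 within the scatter of compound 1, the step from compound 1 to compound 4 is expected to be no larger than the scatter, in no particular direction, so a 1.1-fold higher number from compound 1 to compound 4 (0.02 log units; within the scatter) is the estimate. Compound 4 is therefore expected to give 2.3 ug/mL, most likely between 1.3 ug/mL and 4.5 ug/mL.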

Compound 4, half-maximal inhibitory concentration: 2.01 ug/mL
Compound 4: middle estimate off by 1.1-fold (0.06 log units), on the high side; the range from low to high includes it.
By their numbers in this assay, from the lowest: compounds 4, 3, 1 and 2 (each within the scatter of the next).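

For the compounds shown here, compound 1 and compound 4 are the first pair here that differ in one place only, so the methyl can be judged on its own. In this assay, replacing it with hydrogen on this aromatic carbon, para to a large group, gives a 1.1-fold lower number from compound 1 to compound 4 (0.04 log units; within the scatter) and thus no difference that can be told apart from the variation between repeated measurements. At this position, then, the 4-methylphenyl and the plain phenyl compounds cannot be separated by this read-out, and nothing available here bears on why that is so.

From the compounds shown here alone, the comparison covers only hydrogen and methyl on this one carbon, so it remains open whether an amine, a carboxylic acid or a longer chain such as butyl in the same place would leave the number just as unmoved. It is also open how much the number depends on the shared core, since that part stays the same in all four compounds and no pair shown tests a change there.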